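Joining a dithiocarbamate lactone to a chalcone arm

The compounds below may be only part of what the source reports. "The series", "measured", "known", "first", "only" and "open" are said of these compounds alone.

Measured compounds:
compound 1, `O=C(CSC(=S)N[C@H]1CCOC1=O)Nc1ccc(Br)cc1`: 67400 nM
compound 2, `Cc1ccc(/C=C/C(=O)c2ccc(NC(=O)CCl)cc2)cc1`: 7150 nM

The readout throughout is a functional assay on EC9706 cells (Homo sapiens) for cytotoxicity, read by MTT assay, with a stated time of 72 h; a higher number here means a weaker inhibitor, a lower number a stronger inhibitor. Of the two numbers, compound 1 stands highest, and in this assay compound 1 is the weaker of the pair; compound 2 sits a good way below it, a gap beyond the usual scatter. Compound 3, `O=C(CSC(=S)N[C@H]1CCOC1=O)Nc1ccc(C(=O)/C=C/c2ccccc2)cc1`, is not yet measured. It keeps the core of compound 1 and changes one place: (2-phenylethenyl)carbonyl in place of bromo on an aromatic carbon. The group that enters is the same aryl-bound unsaturated ketone arm that compound 2 carries. On that basis a step downward in this assay is expected for compound 3, of a size clearly beyond the scatter, because compound 2 gives 7150 nM with that arm present. The expected step is a 4.5-fold lower number from compound 1 to compound 3 (0.65 log units; beyond the scatter). The estimate for compound 3 is 15000 nM, with a range from 4000 nM to 50000 nM.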

Compound 3, half-maximal inhibitory concentration: 44900 nM
The estimate for compound 3 lay 3.0-fold (0.48 log units) below the measured number; measured number inside the range.
By their numbers in this assay, from the lowest: compound 2; then compounds 3 and 1 (each within the scatter of the next).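

In this assay the swap of bromo for (2-phenylethenyl)carbonyl on this aromatic carbon gives a 1.5-fold lower number from compound 1 to compound 3 (0.18 log units; within the scatter) and so does not separate the two compounds. This position of the core of compound 1 therefore takes a much larger group, one that brings an extra aromatic ring and a carbonyl, and the number stays within the scatter of the bromo compound. No measurement here offers an explanation for this outcome.

The compounds shown leave open whether a small group on this carbon, such as an amine or a methoxy group, would move the number beyond the scatter. Also open, going by these compounds, is whether a chloro or an amine on the ring of the entering arm would change the result.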